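Replacing fluoro with hydroxy in a potent antiproliferative series

The source may report more compounds than this note shows. Statements on the series, on what has been measured and on what is new or still open speak of the compounds shown alone.

Compound 1 `C=C[C@@H]1C[C@@H](Cc2ccc(OC)c(O)c2)[C@H]2C(=O)C=CC(=C)[C@H]21` gives 0.74 nM
Compound 2 `C=C1C=CC(=O)[C@@H]2[C@H](Cc3ccc(OCOC)c(F)c3)CC[C@H]12` gives 77.4 nM
Compound 3 `C=C1C=CC(=O)[C@@H]2[C@H](Cc3ccc(OC)c(F)c3)CC[C@H]12` gives 1.11 nM

In a functional assay on HCT-116 cells (Homo sapiens) for antiproliferative activity, with a stated time of 72 h (a lower number here means a stronger inhibitor, a higher number a weaker inhibitor), compound 3 gives 1.11 nM and stands within the usual scatter of compound 1, while compound 2 lies far out on the weak side. For the measured compounds named here, that gap is the only measured step in this small set: a 70-fold lower number from compound 2 to compound 3 (1.84 log units; beyond the scatter) with hydrogen in place of methoxy on a saturated chain carbon bound to an oxygen on an aromatic ring.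

Compound 4 `C=C1C=CC(=O)[C@@H]2[C@H](Cc3ccc(OC)c(O)c3)CC[C@H]12` departs from compound 3 by a single change: hydroxy in place of fluoro on an aromatic carbon This places a hydroxy ortho to a methoxy group. Going by the values given here, the measured step does not touch the fluoro, so it shows only that one change on this ring can be large and gives no size for the present swap. Closer evidence comes from compound 1 (0.74 nM) which already carries the hydroxy ortho to a methoxy group, though its core differs from that of compound 4 and no measurement isolates that difference. No step beyond the scatter is therefore expected in this assay in either direction. The expected step is a 1.2-fold lower number from compound 3 to compound 4 (0.09 log units; within the scatter) and it remains an estimate. Compound 4 is estimated at 0.9 nM with an expected range from 0.25 nM to 3.5 nM here.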

Compound 4, half-maximal inhibitory concentration: 3.01 nM
The estimate for compound 4 lay 3.3-fold (0.52 log units) below the measured number; low and high end bracket the measured number.
By their numbers in this assay, from the lowest: compounds 1 and 3 (each within the scatter of the next); then compound 4; then compound 2.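

In this assay the aromatic carbon ortho to a methoxy group proves sensitive to the swap of fluoro for hydroxy, which brings a 2.7-fold higher number from compound 3 to compound 4 (0.43 log units; beyond the scatter) as a modest change that still lies beyond the scatter. Fluoro and hydroxy are therefore not interchangeable at this position, and the fluoro compound is the stronger of the pair. Compound 4 also isolates a second change, hydrogen in place of vinyl on a saturated ring carbon, which gives a 4.1-fold higher number from compound 1 to compound 4 (0.61 log units; beyond the scatter) and shows that the vinyl-bearing compound 1 is the stronger when both carry the hydroxy. The data shown offer no evidence that bears on the cause of either step.

On these data alone, whether an amine or a chlorine on the same aromatic carbon would track with fluoro or with hydroxy remains open. As far as these compounds go, it is also open whether the vinyl step keeps its size with fluoro in place of hydroxy, and whether either step holds outside this assay as well.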